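The source may report more compounds than this note shows. Statements on the series, on what has been measured and on what is new or still open speak of the compounds shown alone.

Working notes on the series. Three compounds sharing one core have been run in an ADME assay on HepG2 cells (Homo sapiens) for cytotoxicity, with a stated time of 3 days; on this read-out lower numbers stand for higher toxicity in this test and higher numbers for lower toxicity in this test: compound 1 `CC(Sc1nnc(-c2ccncc2)s1)C(=O)Nc1c(Cl)cccc1Cl`, compound 2 `O=C(CCSc1nnc(-c2ccncc2)s1)Nc1ccccc1` and compound 3 `CC(CSc1nnc(-c2ccncc2)s1)C(=O)Nc1c(Cl)cccc1Cl`. For compound 1 the read-out is only a limit of the assay, > 50000 nM. For compound 2 the read-out is likewise a limit of the assay, > 50000 nM. For compound 3 the read-out is again a limit of the assay, > 50000 nM. Going by the values given here, every value seen so far therefore sits at the limit of > 50000 nM in this assay, at which 3 of the 3 values shown sit, and compound 2 stands at that limit together with the other two, so no step between measured compounds can be read and no direction is set by the data.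

Compound 4 `O=C(CCSc1nnc(-c2ccncc2)s1)Nc1ccccc1Cl` is the next to be measured in this assay. It differs from compound 2 in one place: chloro in place of hydrogen on an aromatic carbon. With the measured set flat at the limit, no shift beyond the usual scatter is expected for this change. Compound 4 is estimated in this assay at 60000 nM, within 25000 nM to 150000 nM. The step this estimate means is expected to be a step that the limit leaves unreadable from compound 2 to compound 4, most likely again reported as a limit.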

Compound 4, half-maximal cytotoxic concentration: > 50000 nM
Compound 4 gave a limit, no number; the forecaster's own chance of this, stated with the estimate: 75%; the middle value does not contradict the limit.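

Going by these compounds alone, no step from compound 2 to compound 4 can be read in this assay, since both compounds give only a limit: the limit of > 50000 nM in this assay, at which 4 of the 4 values shown sit. The compounds shown leave open which structural change, if any, would give a readable number in this assay.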